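This account rests on a few compounds, and the source may have more. Where it says the series, first, only, none or still open, it means among the compounds named here.

Measured so far in a functional assay on HEL cells (Homo sapiens) for inhibition; on this read-out higher numbers stand for lower toxicity in this test and lower numbers for higher toxicity in this test:
Compound 1 `O=C1c2ccccc2N(Cc2ccccc2Cl)S(=O)(=O)N1Cc1ccccc1Cl`. In this assay compound 1 gives > 200000 nM, a limit of the assay rather than a number.
Compound 2 `O=C1c2ccccc2N(Cc2ccccc2Cl)S(=O)(=O)N1Cc1ccccc1`. In this assay compound 2 gives 88000 nM.
Compound 3 `O=C1c2ccccc2N(Cc2ccccc2Cl)S(=O)(=O)N1COCc1ccccc1`. In this assay compound 3 gives > 50000 nM, again a limit.

Within the data shown here, compound 2 therefore holds the only number in this set; the other two values are limits. Compound 4 `O=C1c2ccccc2N(Cc2ccc(Cl)c(Cl)c2)S(=O)(=O)N1Cc1ccccc1` differs from compound 2 in one place: 3,4-dichlorophenyl in place of 2-chlorophenyl on a saturated chain carbon bound to a sulfonamide nitrogen in a ring. Of the measured steps, only an at least 2.2-fold lower number from compound 1 to compound 2 (0.35 log units; beyond the scatter) is readable, and it runs the opposite way, hydrogen in place of chloro giving the lower number. The steps a step that the two limits leave unreadable from compound 1 to compound 3 and a step that the limit leaves unreadable from compound 2 to compound 3 cannot be sized. Adding a chloro is thus expected to raise the number modestly, a 1.7-fold higher number from compound 2 to compound 4 (0.23 log units; within the scatter). Compound 4 is estimated at 150000 nM in this assay, expected between 60000 nM and 350000 nM.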

Compound 4, half-maximal cytotoxic concentration: > 200000 nM
Compound 4 gave a limit, no number; the forecaster's own chance of this, stated with the estimate: 40%; middle value at least 1.3-fold (0.12 log units) away from the limit.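

In this assay, the place on a saturated chain carbon bound to a sulfonamide nitrogen in a ring now has a readable step: 3,4-dichlorophenyl in place of 2-chlorophenyl gives an at least 2.2-fold higher number from compound 2 to compound 4 (0.35 log units; beyond the scatter). Compound 4 gives > 200000 nM, a limit and not a number. The earlier compounds shown here showed no readable step at this place.

On these data alone, the full size of this step stays unknown, and the change alters chlorine count and placement together, so neither can be credited alone: the limit of > 200000 nM in this assay, at which 2 of the 4 values shown sit. How a carboxylic acid or a dimethylamino group at this place would read remains open.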